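The source may report more compounds than this note shows. Statements on the series, on what has been measured and on what is new or still open speak of the compounds shown alone.

For the measured compounds named here, compound 2, `COc1ccc2c(OCC[C@@H]3NC(=O)N(C)CCCC/C=C\[C@@H]4C[C@@]4(C(=O)NS(=O)(=O)C4(C)CC4)NC3=O)cc(-c3nc(C(C)C)cs3)nc2c1Cl`, gives 37400 nM in an ADME assay on cells (Homo sapiens) for activation (on this read-out lower numbers stand for higher toxicity in this test and higher numbers for lower toxicity in this test), the lower of the two numbers measured so far, though the gap to compound 1 is within the scatter. Compound 1, `COc1ccc2c(OCC[C@@H]3NC(=O)N(C)CCCC/C=C\[C@@H]4C[C@@]4(C(=O)NS(=O)(=O)N(C)C)NC3=O)cc(-c3nc(C(C)C)cs3)nc2c1Cl`, gives 47800 nM in this assay, and the step of a 1.3-fold lower number from compound 1 to compound 2 (0.11 log units; within the scatter) was within the scatter. Compound 3, `C#C[C@@H]1CCCN1S(=O)(=O)NC(=O)[C@@]12C[C@H]1/C=C\CCCCN(C)C(=O)N[C@@H](CCOc1cc(-c3nc(C(C)C)cs3)nc3c(Cl)c(OC)ccc13)C(=O)N2`, has not yet been measured. Compared with compound 2 it carries 2-ethynylpyrrolidin-1-yl in place of 1-methylcyclopropyl on a sulfonyl sulfur. Going by the values given here, the only measured step that bears on this site is a 1.3-fold lower number from compound 1 to compound 2 (0.11 log units; within the scatter), which exchanged the group on the same sulfonyl sulfur and stayed within the scatter; no other step is available. A similarly small step, in no direction beyond the scatter, is therefore expected, namely a 1.1-fold lower number from compound 2 to compound 3 (0.03 log units; within the scatter). On that basis compound 3 is estimated at 35000 nM in this assay, with a range from 15000 nM to 80000 nM.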

Compound 3, half-maximal cytotoxic concentration: 21200 nM
Estimate against measurement, compound 3: 1.7-fold (0.22 log units) above, within the range that was stated.
By their numbers in this assay, from the lowest: compounds 3, 2 and 1 (each within the scatter of the next, the first and the last beyond it).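

In this assay, placing 2-ethynylpyrrolidin-1-yl on the sulfonyl sulfur gives a 1.8-fold lower number from compound 2 to compound 3 (0.25 log units; within the scatter), and, against the other group, a 2.3-fold lower number from compound 1 to compound 3 (0.35 log units; beyond the scatter). For the compounds shown here, this is the first step at this position to pass beyond the scatter, although it is modest and appears only against dimethylamino, not against 1-methylcyclopropyl. Nothing available accounts for this difference.

The compounds shown leave open whether the step belongs to the five-membered ring or to the triple bond, a question that a plain pyrrolidin-1-yl or a 2-ethylpyrrolidin-1-yl group on the same sulfur would address. They also leave open what the other arrangement at the defined stereocentre of the 2-ethynylpyrrolidin-1-yl group, or a six-membered piperidin-1-yl ring, would give in this read-out.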